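The source may hold more compounds than are shown below. What is called first, only, known or untested is meant among the compounds shown, and "the series" means these compounds.

Compound 2 `CNC(=O)/C=C1/COc2cc(OS(=O)(=O)c3cccc(Cl)c3)ccc21` carries a 3-chlorophenyl on its sulfonyl sulfur. In an assay (strain Sprague-Dawley) for inhibition of Amine oxidase [flavin-containing] B (Rattus norvegicus), read by spectrophotometry, with a stated time of 5 min, tested at 10 uM (on this read-out lower numbers stand for less inhibition and higher numbers for more inhibition at the one concentration tested (going by the name of the read-out)), compound 2 gives 0%. Compound 1 `CNC(=O)/C=C1/COc2cc(OS(=O)(=O)c3ccccc3)ccc21` gives 0% in this assay, and the step is no change at the digits printed from compound 1 to compound 2 (within the scatter). Compound 3 `CNC(=O)/C=C1/COc2cc(OS(=O)(=O)c3ccc([N+](=O)[O-])cc3)ccc21` gives 13% in this assay; here the step is a number 13 percentage points higher from compound 1 to compound 3 (beyond the scatter). Compound 2 thus stands level with compound 1 at the digits shown, the two together the lowest of the three numbers, while a number 13 percentage points higher from compound 2 to compound 3 (beyond the scatter).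

Compound 4 `CNC(=O)/C=C1/COc2cc(OS(=O)(=O)c3ccc(OC)cc3)ccc21` differs from compound 2 in one place: 4-methoxyphenyl in place of 3-chlorophenyl on a sulfonyl sulfur. Among the measured compounds shown here, the only measured step at the same place is a number 13 percentage points higher from compound 2 to compound 3 (beyond the scatter), which was modest. The other two aryl changes were no larger: no change at the digits printed from compound 1 to compound 2 (within the scatter) and a number 13 percentage points higher from compound 1 to compound 3 (beyond the scatter). A step of similar or smaller size is therefore expected in this assay, upward if at all, and quite possibly none beyond the scatter. For compound 4 the expected value in this assay is 5%, within a range of 0% to 18%. That estimate means an expected step of a number 5 percentage points higher from compound 2 to compound 4 (within the scatter).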

Compound 4, a percentage reported as inhibition, at one concentration (the size of the read-out at that concentration, not a potency): 0%
Estimate against measurement, compound 4: 5 percentage points above; measured number inside the range.
By their numbers in this assay, from the lowest: compounds 1, 2 and 4 (each within the scatter of the next); then compound 3.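

In this assay, 4-methoxyphenyl on the sulfonyl sulfur reads like the two groups that gave no inhibition: there is no change at the digits printed from compound 1 to compound 4 (within the scatter) and no change at the digits printed from compound 2 to compound 4 (within the scatter) for this change. The comparison with the nitro compound is the new part, with a number 13 percentage points lower from compound 3 to compound 4 (beyond the scatter) when methoxy replaces nitro on an aromatic carbon. A group at that carbon is therefore not enough on its own, since of nitro and methoxy only nitro goes with a number beyond the scatter of the other three compounds.

On these data alone, whether an amine or a carboxylic acid in place of the nitro would also stand apart from compounds 1, 2 and 4 remains open. Nothing available here explains why nitro and methoxy differ in this assay.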